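A few compounds are considered here, and "the series" means these few. Any claim that something is new, unique, unknown or untested is made for them only; others in the source may bear on it.

In an ADME assay on microsomes (Homo sapiens) for metabolic stability (on this read-out higher numbers stand for a longer-lived compound and lower numbers for a shorter-lived compound), compound 1 `Cc1coc(Cn2nc3ccc(-c4ccc(OC(F)(F)F)cc4)cn3c2=O)n1` gives 2.4 h and compound 2 `Cc1noc(Cn2nc3ccc(-c4ccc(Oc5ccc(F)cc5)cc4)cn3c2=O)n1` gives 2.12 h. These two values lie within the usual scatter of each other, so compound 1 cannot be ranked against compound 2. Compound 3 `Cc1nc(Cn2nc3ccc(-c4ccc(OC(F)(F)F)cc4)cn3c2=O)no1` is not yet measured. It keeps the core of compound 1 but carries 5-methyl-1,2,4-oxadiazol-3-yl in place of 4-methyl-1,3-oxazol-2-yl on a saturated chain carbon bound to an aromatic nitrogen. Within the data shown here, no measured pair here differs in one place only, so the data give no direct guide to this swap. The starting point for an expectation is therefore compound 1 at 2.4 h, with no step beyond the scatter expected and no firm direction. The expected step is a 1.2-fold lower number from compound 1 to compound 3 (0.08 log units; within the scatter). For compound 3, the estimated half-life is 2 h, with an expected range of 1 h to 3.8 h.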

Compound 3, half-life: 6.58 h
Beside the measured number, compound 3's estimate is 3.3-fold (0.52 log units) below it; measured number outside the range, above it.
By their numbers in this assay, from the lowest: compounds 2 and 1 (each within the scatter of the next); then compound 3.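

In this assay the ring on the saturated chain carbon bound to an aromatic nitrogen now proves to matter: 5-methyl-1,2,4-oxadiazol-3-yl in place of 4-methyl-1,3-oxazol-2-yl gives a 2.7-fold higher number from compound 1 to compound 3 (0.44 log units; beyond the scatter), a modest step. Compound 1 and compound 2 differ in more than one place, so they could not single out this position. The heavy atom count stays the same in this swap, so exchanging atoms within the ring is enough to shift the number, and nothing measured here explains why.

Going by these compounds, whether the same gain would appear with another group on the rest of the molecule remains open, as this is a single pair. On these data alone, it is also open how a ring-free group at this place, such as an amide or a carboxylic acid, would compare.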